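Swapping 4-chlorophenyl for 2-methylphenyl on the shared core

The source may report more compounds than this note shows. Statements on the series, on what has been measured and on what is new or still open speak of the compounds shown alone.

Values so far in a functional assay on MOLT-4 cells (Homo sapiens) for antiproliferative activity, read by MTT assay, with a stated time of 72 h; on this read-out higher numbers stand for weaker inhibition and lower numbers for stronger inhibition:
Compound 1 `O=C1C=C(N2CCN(c3ccccc3Cl)CC2)C(=O)c2c(O)cccc21` gives 27600 nM
Compound 2 `O=C1C=C(N2CCC(c3ccccc3)CC2)C(=O)c2c(O)cccc21` gives 2700 nM
Compound 3 `O=C1C=C(N2CCC(c3ccc(Cl)cc3)CC2)C(=O)c2c(O)cccc21` gives > 50000 nM

Compound 3 stands at the limit of > 50000 nM in this assay, at which 1 of the 3 values shown sits, and that reading is a limit, not a number.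

Compound 4 `Cc1ccccc1C1CCN(C2=CC(=O)c3cccc(O)c3C2=O)CC1` keeps the core of compound 3 and changes one group: 2-methylphenyl in place of 4-chlorophenyl on a saturated ring carbon. In words, 2-methylphenyl replaces 4-chlorophenyl on a saturated ring carbon.

Among the measured compounds shown here, one measured step bears on this change. It is an at least 18-fold higher number from compound 2 to compound 3 (1.26 log units; beyond the scatter), with chloro in place of hydrogen on an aromatic carbon. Compound 4 carries no chloro, so that large step may be largely undone, and the direction expected in this assay is toward a lower number. For the measured compounds named here, no measured step covers the methyl group, so compound 4 is not expected to match compound 2 at 2700 nM with any confidence.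

The step expected is an at least 6.2-fold lower number from compound 3 to compound 4 (0.79 log units; beyond the scatter), a large one.

Compound 4 is estimated at 8000 nM, with an expected range from 1500 nM to 40000 nM.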

Compound 4, half-maximal inhibitory concentration: > 50000 nM
Compound 4 gave a limit, no number (the forecaster's own chance of this, stated with the estimate: 15%); middle value at least 6.2-fold (0.79 log units) away from the limit.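

In this assay, methyl in place of hydrogen on the aromatic ring gives an at least 18-fold higher number from compound 2 to compound 4 (1.26 log units; beyond the scatter), so the large loss seen on adding chloro is not unique to chloro. Of the three compounds with an aromatic ring on this saturated ring carbon, only compound 2, whose aromatic ring carries neither group, gives a readable number. Compound 3 and compound 4 both read as limits, not numbers, so the step between them cannot be read: the limit of > 50000 nM in this assay, at which 2 of the 4 values shown sit.

As far as these compounds go, it stays open whether 4-methylphenyl or 2-chlorophenyl in this place would also read as a limit, which would help separate the kind of group from where it sits on the aromatic ring. The compounds shown also do not tell how a fluoro group or an amine on that ring would behave.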